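The source may hold more compounds than are shown below. What is called first, only, known or untested is meant among the compounds shown, and "the series" means these compounds.

Series notes. Compound 1 `N#C/C(=C\c1c(F)c(F)c(F)c(F)c1F)C(=O)c1ccc[nH]1` is the ketone member of the set; in a functional assay on SW480 cells (Homo sapiens) for inhibition, read by MTT assay, with a stated time of 72 h (on this read-out lower numbers stand for stronger inhibition of growth and higher numbers for weaker inhibition of growth), compound 1 reports only a limit, > 100000 nM. Compound 2 `N#C/C(=C\c1ccc[nH]1)C(=O)NCc1ccc(Cl)c(Cl)c1` carries the amide to the dichlorophenylmethyl group with a 1H-pyrrol-2-yl on the chain; in this assay compound 2 likewise reports only a limit, > 50000 nM. Among the compounds with values here, compound 3 `N#C/C(=C\c1ccccc1)C(=O)NCc1ccc(Cl)c(Cl)c1` gives 49000 nM in this assay, and that is the only number in the set. For compound 1 the value is a limit, (the limit of > 100000 nM in this assay, at which 1 of the 3 values shown sits). For compound 2 the value is a limit, (the limit of > 50000 nM in this assay, at which 1 of the 3 values shown sits). The step of an at least 1.0-fold lower number from compound 2 to compound 3 (0.00 log units; that floor lies within the scatter) reaches only a floor, and that floor lies within the scatter, so nothing can be said of order between compound 2 and compound 3.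

Compound 4 `COc1ccc(/C=C(\C#N)C(=O)NCc2ccc(Cl)c(Cl)c2)cc1` differs from compound 3 by methoxy in place of hydrogen on an aromatic carbon. Within the data shown here, no measured step in the set alters a substituent on the six-membered ring; the sole measured step, an at least 1.0-fold lower number from compound 2 to compound 3 (0.00 log units; that floor lies within the scatter), exchanges the ring itself and sits within the scatter, so it gives no direction for the methoxy. For this assay the expected step is a 1.1-fold lower number from compound 3 to compound 4 (0.04 log units; within the scatter), that is, none beyond the scatter, with a real chance that only a limit is returned. Compound 4 is estimated at 45000 nM, with a range from 15000 nM to 150000 nM.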

Compound 4, concentration for 50% growth inhibition: 95000 nM
Estimate against measurement, compound 4: 2.1-fold (0.32 log units) below; low and high end bracket the measured number.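

In this assay, within the data shown here, compound 3 and compound 4 form the only pair in the set with a number at both ends, and methoxy in place of hydrogen gives a 1.9-fold higher number from compound 3 to compound 4 (0.29 log units; within the scatter). This is also the first readable test of a substituent on an aromatic carbon of the six-membered ring, para to a large group, and phenyl to 4-methoxyphenyl leaves no difference beyond the scatter, while the step between compound 2 and compound 4 cannot be read. Nothing at hand gives a cause for the step from methoxy.

Going by these compounds, it remains open whether another group at this same place, such as hydroxy, an amine or a carboxylic acid, would give a step beyond the scatter, as one substituent at one place defines no trend for the ring. Also open, on these data alone, is the other end of the molecule, where the dichlorophenylmethyl group is held constant across compound 2, compound 3 and compound 4, so a longer chain between the amide nitrogen and that ring, or a ring carrying a single chlorine, remains an untested variation in this set.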